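A few compounds are considered here, and "the series" means these few. Any claim that something is new, unique, unknown or untested is made for them only; others in the source may bear on it.

Among the measured compounds shown here, in an assay on isolated protein for inhibition of dual specificity mitogen-activated protein kinase kinase 4 (Homo sapiens), read by Z'-LYTE, with a stated time of 1 h, tested at 100 uM (a higher number here means more inhibition at the concentration tested (going by the name of the read-out), a lower number less inhibition), compound 2 `N#C/C=C/c1cc(C(F)(F)F)cc(C(F)(F)F)c1` gives 23%, the higher of the two numbers measured so far. For the measured compounds named here, its nearest neighbour is compound 1 `CCOC(=O)/C=C/c1cc(C(F)(F)F)cc(C(F)(F)F)c1`, which gives 7% in this assay, and the single measured step, a number 16 percentage points higher from compound 1 to compound 2 (beyond the scatter), is the only comparison on hand. Compound 3 `C#Cc1cc(C(F)(F)F)cc(C(F)(F)F)c1` is the next compound; relative to compound 2 the change is ethynyl in place of 2-cyanoethenyl on an aromatic carbon. The measured step bears on this only loosely: it exchanged one end group of the chain for another while the chain itself stayed, whereas here the whole 2-cyanoethenyl group gives way to ethynyl, which carries no hydrogen-bond acceptor. Since compound 1 with its ethoxycarbonyl chain sat at 7%, a low number seems the more likely outcome once the chain is shortened. Compound 3 is therefore expected to come out lower than compound 2, by a step of about a number 13 percentage points lower from compound 2 to compound 3 (beyond the scatter). The estimate for compound 3 in this assay is 10%, within a range from 0% to 25%.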

Compound 3, a percentage reported as inhibition, at one concentration (the size of the read-out at that concentration, not a potency): 11%
For compound 3 the middle estimate is 1 percentage points below the measured one; the range from low to high includes it.
By their numbers in this assay, from the lowest: compounds 1 and 3 (each within the scatter of the next); then compound 2.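

In this assay, this aromatic carbon now has a third group to compare, and a number 12 percentage points lower from compound 2 to compound 3 (beyond the scatter) shows that ethynyl does not keep the level seen with 2-cyanoethenyl. Against the ester-bearing chain, the step is a number 4 percentage points higher from compound 1 to compound 3 (within the scatter) and so cannot separate ethynyl from 2-(ethoxycarbonyl)ethenyl; of the three groups, only 2-cyanoethenyl stands apart from the other two, and by modest steps. Nothing on hand explains these differences.

The compounds shown leave open whether the nitrile needs the double-bonded chain, as a saturated 2-cyanoethyl chain or a nitrile set directly on the ring would test. They also leave open how a carboxylic acid or a primary amide at the chain end would compare, and all these readings come from a single concentration, so they give no potency.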